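The source may report more compounds than this note shows. Statements on the series, on what has been measured and on what is new or still open speak of the compounds shown alone.

In a toxicity assay on HT-29 cells (Homo sapiens) for cytotoxicity (on this read-out higher numbers stand for lower toxicity in this test and lower numbers for higher toxicity in this test), compound 2 (`CC(C)n1nc(C(=O)N[C@H]2COc3ccccc3N(C)C2=S)nc1Cc1ccccc1`) gives > 100000 nM as its reading, which is a limit and not a number. Compound 1 (`CN1C(=S)[C@@H](NC(=O)c2nc(Cc3ccccc3)n(C)n2)COc2ccccc21`) gives > 100000 nM in this assay as its reading, also a limit. Compound 3 (`CC(C)Cn1nc(C(=O)N[C@H]2COc3ccccc3N(C)C2=S)nc1Cc1ccccc1`) gives > 100000 nM in this assay as its reading, again a limit. For the measured compounds named here, the whole record so far is the limit of > 100000 nM in this assay, at which 3 of the 3 values shown sit, and no compound has a number to its name.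

Compound 4 (`CN1C(=S)[C@@H](NC(=O)c2nc(Cc3ccccc3)n(CCC(F)(F)F)n2)COc2ccccc21`) differs from compound 2 at a single place on the shared core. The change is 3,3,3-trifluoropropyl in place of isopropyl on an aromatic nitrogen in all, with 3,3,3-trifluoropropyl in place of isopropyl on an aromatic nitrogen.

Going by the values given here, three measured steps bear on this, each a change of the group at that same nitrogen or of the chain on it. They are a step that the two limits leave unreadable from compound 1 to compound 2 and a step that the two limits leave unreadable from compound 2 to compound 3 and a step that the two limits leave unreadable from compound 1 to compound 3 so none of them has a size that can be read.

Because of the limit of > 100000 nM in this assay, at which 3 of the 3 values shown sit, the expectation in this assay is no step beyond the scatter, in neither direction. The estimated step is a number no higher from compound 2 to compound 4 (the limit leaves the size open) on this reasoning. For compound 4 the estimate is 100000 nM with an expected range from 50000 nM to 200000 nM and the reading is expected most likely to stop at the limit again.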

Compound 4, half-maximal cytotoxic concentration: > 100000 nM
Compound 4 gave a limit, no number; the forecaster's own chance of this, stated with the estimate: 85%; the middle value lies on the limit itself.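

In this assay compound 4 gives > 100000 nM, which is a limit and not a number. None of the steps joining compound 4 to compound 1, compound 2 or compound 3 can be read. The compounds shown leave open whether the group on the aromatic nitrogen makes any difference to the reading in this assay, since none of the four compounds has a number.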